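Adding a Methoxy Group to Compound 1

The source may report more compounds than this note shows. Statements on the series, on what has been measured and on what is new or still open speak of the compounds shown alone.

Compound 1 `O=C1CNc2nc(Nc3ccccc3)ncc2N1` is the parent. In a functional assay on MDA-MB-231 cells (Homo sapiens) for cytotoxicity, read by MTT assay, with a stated time of 48 h (a higher number here means a weaker inhibitor, a lower number a stronger inhibitor), compound 1 gives > 100000 nM, which is a limit of the assay rather than a number. Compound 2 `O=C1CNc2nc(Nc3ccc(F)cc3)ncc2N1` carries fluoro in place of hydrogen on an aromatic carbon. In this assay compound 2 gives > 100000 nM, again a limit. The step that the two limits leave unreadable from compound 1 to compound 2 is thus of unreadable size, both values sitting at the limit of > 100000 nM in this assay, at which 2 of the 2 values shown sit. Compound 3 `COc1cccc(Nc2ncc3c(n2)NCC(=O)N3)c1` differs from compound 1 by methoxy in place of hydrogen on an aromatic carbon, meta to a large group. Going by the values given here, no measured step reads on this change, and compound 1 stands only at a limit, so no shift beyond the scatter is expected in this assay. Compound 3 is estimated at 150000 nM (range 40000 nM to 500000 nM), the expected step being a step that the limit leaves unreadable from compound 1 to compound 3.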

Compound 3, half-maximal inhibitory concentration: 93200 nM
The estimate for compound 3 lay 1.6-fold (0.21 log units) above the measured number; low and high end bracket the measured number.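

With methoxy in place of hydrogen on an aromatic carbon, meta to a large group, this assay returns a number rather than a limit: the limit of > 100000 nM in this assay, at which 2 of the 3 values shown sit. The change gives an at least 1.0-fold lower number from compound 1 to compound 3 (0.03 log units; that floor lies within the scatter), so this position tolerates methoxy, but the data show no gain beyond the scatter. Compound 3 therefore marks where a readable value begins, not a clear improvement on compound 1.

On these data alone, whether an amine or a carboxylic acid on the same aromatic carbon would move the number beyond the scatter stays open. So does the effect of a longer chain such as ethoxy there.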